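The source may hold more compounds than are shown below. What is called first, only, known or untested is meant among the compounds shown, and "the series" means these compounds.

Compound 1 `COc1ccc([C@H]2CC(=O)N(c3cccc(C)c3)C2)cc1OC1CCCC1`: > 10000 nM (a limit)
Compound 2 `COc1ccc([C@H]2CC(=O)N(c3cccc(NCC4CCOC4)c3)C2)cc1OC1CCCC1`: > 10000 nM (a limit)
Compound 3 `COc1ccc([C@H]2CC(=O)N(c3cccc(NCc4ccoc4)c3)C2)cc1OC1CCCC1`: not yet measured

In a functional assay on HEK293 cells (Homo sapiens) for cytotoxicity (on this read-out higher numbers stand for lower toxicity in this test and lower numbers for higher toxicity in this test), compound 2 gives > 10000 nM as a limit of the assay, not a number. Compound 1 likewise gives > 10000 nM as a limit. All that is known so far is the limit of > 10000 nM in this assay, at which 2 of the 2 values shown sit.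

The change to compound 3 is furan-3-yl in place of oxolan-3-yl on a saturated chain carbon bound to a nitrogen on an aromatic ring. Going by the values given here, the only measured step, a step that the two limits leave unreadable from compound 1 to compound 2, has no readable size and concerns a different change, so it gives no direction. In this assay no step beyond the usual scatter is expected, and another limit is the likeliest report. The estimated step is a step that the limit leaves unreadable from compound 2 to compound 3 and rests on this expectation alone. For compound 3 the expected value is 12000 nM with an estimated range from 5000 nM to 30000 nM.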

Compound 3, half-maximal cytotoxic concentration: > 10000 nM
Compound 3: a limit, no number (the forecaster's own chance of this, stated with the estimate: 80%); the middle value does not contradict the limit.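

No new step can be read among compound 1, compound 2 and compound 3 in this assay, since all three report a limit and not a number: the limit of > 10000 nM in this assay, at which 3 of the 3 values shown sit. The compounds shown leave open how far each lies from that limit, and whether furan-3-yl and oxolan-3-yl differ at all in this assay.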